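Cyclopropyl for cyclopentyl on the amino nitrogen

The source may hold more compounds than are shown below. What is called first, only, known or untested is meant among the compounds shown, and "the series" means these compounds.

In a functional assay on A549 cells (Homo sapiens) for antiproliferative activity, read by sulforhodamine B assay, with a stated time of 48 h (a lower number here means a stronger inhibitor of growth, a higher number a weaker inhibitor of growth), compound 1 `COc1ccc(Nc2nc(NC3CCCC3)c3ccccc3n2)cc1` gives 10100 nM. Compound 2 `CNc1nc(Nc2ccc(OC)cc2)nc2ccccc12` gives 16100 nM. Within the data shown here, these two values lie within the scatter of each other, so compound 1 is not separated from the only other measured member of the series.

Compound 3 `COc1ccc(Nc2nc(NC3CC3)c3ccccc3n2)cc1` keeps the core of compound 1 and carries cyclopropyl in place of cyclopentyl on a nitrogen on an aromatic ring, a change from cyclopentylamino to cyclopropylamino: cyclopropyl in place of cyclopentyl on a nitrogen on an aromatic ring.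

Among the measured compounds shown here, one measured step bears on this change: a 1.6-fold higher number from compound 1 to compound 2 (0.20 log units; within the scatter). For the measured compounds named here, it replaces cyclopentyl with methyl at the same place, and it is the only evidence available. Going by the values given here, no measured compound yet shows what a small ring does there. Cyclopropyl is counted as lying in size between methyl and cyclopentyl, so no step beyond the scatter is expected in this assay, with at most a slight drift towards a higher number. The expected step is a 1.2-fold higher number from compound 1 to compound 3 (0.09 log units; within the scatter). For compound 3 the estimated value is 12500 nM, with an expected range of 6000 nM to 26000 nM.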

Compound 3, concentration for 50% growth inhibition in the A549 assay: 13000 nM
For compound 3 the middle estimate is 1.0-fold (0.02 log units) below the measured one; the range from low to high includes it.
By their numbers in the A549 assay, from the lowest: compounds 1, 3 and 2 (each within the scatter of the next).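

In the A549 assay compound 3 gives 13000 nM with a 1.3-fold higher number from compound 1 to compound 3 (0.11 log units; within the scatter) and a 1.2-fold lower number from compound 2 to compound 3 (0.09 log units; within the scatter) so cyclopropyl, cyclopentyl and methyl on this nitrogen are not separated from one another. The earlier pair compared only a five-membered carbon ring with methyl; compound 3 adds a three-membered carbon ring at the same place, and a reading within the scatter of both now covers a ring of either size as well as the open methyl group, so across these three compounds the size of the group on this nitrogen has no resolved effect on the reading. In a physicochemical assay for lipophilicity, read by HPLC, measured as octanol-water partition, with a stated time of 24 h (a higher number here means a more lipophilic compound, a lower number a more polar compound), compound 1 gives > 5 which is a limit of the assay and not a number. In the physicochemical assay the entry for compound 3 reads "not determined" (no result reported) so no step can be read there and nothing in that assay offers a cause for the readings: the limit of > 5 in the physicochemical assay, at which 1 of the 2 values shown sits.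

Still open, as far as these compounds go, is whether a group of another kind on this nitrogen, such as a chain ending in a tertiary amine, a carboxylic acid or a longer alkyl chain, would give a step beyond the scatter. Also open, from the compounds shown here alone, is whether any change away from this nitrogen, on the rest of the shared core, would move the number at all.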